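This account rests on a few compounds, and the source may have more. Where it says the series, first, only, none or still open, it means among the compounds named here.

Measured compounds:
compound 1 `O=C(Oc1ccc2ccc(=O)oc2c1CN1CCc2ccccc2C1)c1ccccc1`: > 100000 nM
compound 2 `COc1ccc2c(=O)c(Cc3c(OC(C)=O)ccc4c(C)cc(=O)oc34)c(N(C)C)oc2c1`: 42000 nM

Two compounds have readings in an ADME assay on MT4 cells (Homo sapiens) for cytotoxicity, read by MTT assay, with a stated time of 96 h; a lower number here means that less compound is tolerated, a higher number that more compound is tolerated. For compound 1 the reading is a limit of the assay rather than a number, (the limit of > 100000 nM in this assay, at which 1 of the 2 values shown sits). Compound 2 gives 42000 nM in this assay. Going by the values given here, compound 1 therefore stands at the limit end of the two readings, and no step between measured compounds that differ in one place is available to guide the next change.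

Compound 3 `Cc1cc(=O)oc2c(CN3CCc4ccccc4C3)c(OC(=O)c3ccccc3)ccc12` differs from compound 1 by methyl in place of hydrogen on an aromatic carbon. Among the compounds with values here, no measured step bears on this change. In this assay a step no larger than the usual scatter is expected, in no particular direction, and the reading for compound 3 may again be a limit. Compound 3 is expected to give 100000 nM, with a range from 50000 nM to 200000 nM. The expected step is a number no higher from compound 1 to compound 3 (the limit leaves the size open).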

Compound 3, half-maximal cytotoxic concentration: > 100000 nM
Compound 3 gave a limit, no number; the forecaster's own chance of this, stated with the estimate: 70%; the middle value sits exactly at the limit.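

Compound 1 and compound 3 both give a limit rather than a number in this assay, so no step can be read between them: the limit of > 100000 nM in this assay, at which 2 of the 3 values shown sit.

The compounds shown leave open whether methyl in place of hydrogen on an aromatic carbon shifts the reading in this assay at all, and in which direction.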